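Methoxy to methyl on the anilino ring of the shared core

A few compounds are considered here, and "the series" means these few. Any claim that something is new, unique, unknown or untested is made for them only; others in the source may bear on it.

Of the compounds shown here, two on the shared core have numbers so far. Compound 1 `[O-][n+]1nc(NCc2ccccc2Cl)[n+]([O-])c2ccccc21` carries a benzylamine side group; in a functional assay on PC-3 cells (Homo sapiens) for cytotoxicity, read by MTT assay, with a stated time of 48 h (a higher number here means a weaker inhibitor, a lower number a stronger inhibitor), compound 1 gives 10600 nM. Compound 2 `COc1ccc(Nc2n[n+]([O-])c3ccccc3[n+]2[O-])cc1` carries an anilino side group with a methoxy group; in this assay compound 2 gives 12000 nM. Compound 2 stands level with compound 1: the gap between the two numbers lies within the usual scatter of repeated measurements, so nothing separates them.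

Compound 3 `Cc1ccc(Nc2n[n+]([O-])c3ccccc3[n+]2[O-])cc1` is the next point in the series. It differs from compound 2 in one place: methyl in place of methoxy on an aromatic carbon, para to a large group. No measured pair in the series isolates this change, so its size is not anchored by any shown step. Among the compounds with values here, with only two numbers at hand, both close to each other, the expectation is a step in this assay that does not go beyond the scatter, in either direction.

The estimated step of a 1.1-fold lower number from compound 2 to compound 3 (0.04 log units; within the scatter) is therefore expected to be small. For compound 3 the expected value in this assay is 11000 nM, with a range from 5000 nM to 25000 nM.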

Compound 3, half-maximal inhibitory concentration: 10300 nM
Compound 3: middle estimate off by 1.1-fold (0.03 log units), on the high side, within the range that was stated.
By their numbers in this assay, from the lowest: compounds 3, 1 and 2 (each within the scatter of the next).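

In this assay, within the data shown here, the replacement of methoxy by methyl on an aromatic carbon, para to a large group, gives a 1.2-fold lower number from compound 2 to compound 3 (0.07 log units; within the scatter) and is the first step that isolates a single change at this position. The methoxy oxygen, with the hydrogen-bond acceptor counted for it, can therefore leave this position without a reading beyond the scatter, at least when methyl enters in its place. Nothing on hand bears on why this step stays so small, and the series offers no measurement that could account for it.

Methoxy and methyl are the only groups at this position in the compounds shown, so it remains open whether an amine, a carboxylic acid or a longer chain such as butoxy would move the number beyond the scatter. As far as these compounds go, compound 1 differs from compound 2 and compound 3 in more than one place, so it gives no reading on this position, and how the benzylamine side group would respond to the same change also remains open.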